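A Benzoyl in Place of Nitro: An Untested Step

This account rests on a few compounds, and the source may have more. Where it says the series, first, only, none or still open, it means among the compounds named here.

Compound 2 `O=C1Nc2ccc([N+](=O)[O-])cc2/C1=C\c1cccc(OCc2cn(Cc3ccccc3)nn2)c1` is known only through a limit. In a functional assay on BT-549 cells (Homo sapiens) for inhibition, read by MTT assay, with a stated time of 48 h (on this read-out higher numbers stand for weaker inhibition and lower numbers for stronger inhibition), compound 2 gives > 50000 nM, a limit of the assay rather than a number. Compound 1 `O=C1Nc2ccc(Br)cc2/C1=C/c1cccc(OCc2cn(Cc3ccccc3)nn2)c1` is known the same way. In this assay compound 1 gives > 50000 nM, again a limit. Within the data shown here, both readings sit at the same boundary, (the limit of > 50000 nM in this assay, at which 2 of the 2 values shown sit), so no step between them can be sized. Compound 3 `O=C1Nc2ccc(C(=O)c3ccccc3)cc2/C1=C\c1cccc(OCc2cn(Cc3ccccc3)nn2)c1` has not yet been tested. It differs from compound 2 in one place: benzoyl in place of nitro on an aromatic carbon. Among the measured compounds shown here, with two limits and no measured step, nothing here points to a change beyond the usual scatter in this assay. The step is expected to be roughly an at least 1.2-fold lower number from compound 2 to compound 3 (0.09 log units; that floor lies within the scatter). Compound 3 is therefore estimated at 40000 nM, within a range from 8000 nM to 200000 nM, with a fair chance that only a limit is reported again.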

Compound 3, half-maximal inhibitory concentration: > 50000 nM
Compound 3: a limit, no number; the forecaster's own chance of this, stated with the estimate: 65%; middle value at least 1.2-fold (0.09 log units) from the limit.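

In this assay, among these compounds, compound 3 gives > 50000 nM as a limit and not a number, so no step from compound 2 to compound 3 can be read: the limit of > 50000 nM in this assay, at which 3 of the 3 values shown sit. The compounds shown leave open whether benzoyl and nitro on an aromatic carbon differ at all in this assay as neither compound 2 nor compound 3 gives a number there.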